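Swapping the aryl group in a quinoline solubility series

This account rests on a few compounds, and the source may have more. Where it says the series, first, only, none or still open, it means among the compounds named here.

Compound 1 `COc1cccc(CNCCCNc2ccnc3cc(-c4ccc(C(C)(C)C)cc4)ccc23)c1O` gives 32000 nM in a physicochemical assay for solubility, with a stated time of 18 h, at pH 7.4; on this read-out higher numbers stand for higher solubility and lower numbers for lower solubility. Compound 2 `CCC(CC)c1ccc2c(NCCCNCc3cc(F)ccc3OC)ccnc2c1` gives 4200 nM. Compound 3 `COc1ccc(F)cc1CNCCCNc1ccnc2cc(Oc3cccc(N(C)C)c3)ccc12` gives 14500 nM.

Compound 3 stands second highest of the three numbers in this assay: compound 1 reads higher and compound 2 lower. Compound 4 `COc1ccc(F)cc1CNCCCNc1ccnc2cc(-c3ccc(C(C)(C)C)cc3)ccc12` differs from compound 3 by 4-(tert-butyl)phenyl in place of 3-(dimethylamino)phenoxy on an aromatic carbon. Going by the values given here, the only measured step at this position is a 3.5-fold higher number from compound 2 to compound 3 (0.54 log units; beyond the scatter), which went the other way, replacing a saturated chain. Among the compounds with values here, compound 1 carries the same 4-(tert-butyl)phenyl group on a different benzylamine and gives 32000 nM, so no single measured step exactly mirrors this change. Compound 4 is therefore expected to stay close to compound 3, with a step of a 1.2-fold lower number from compound 3 to compound 4 (0.08 log units; within the scatter), giving an estimated 12000 nM between 4000 nM and 35000 nM.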

Compound 4, solubility: 32000 nM
Estimate against measurement, compound 4: 2.7-fold (0.43 log units) below; the range from low to high includes it.
By their numbers in this assay, from the lowest: compound 2; then compound 3; then compounds 1 and 4 (each within the scatter of the next).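

In this assay this aromatic carbon gives a 2.2-fold higher number from compound 3 to compound 4 (0.34 log units; beyond the scatter) when 4-(tert-butyl)phenyl replaces 3-(dimethylamino)phenoxy, and a 7.6-fold higher number from compound 2 to compound 4 (0.88 log units; beyond the scatter) when it replaces pentan-3-yl. On the saturated chain carbon, 5-fluoro-2-methoxyphenyl in place of 2-hydroxy-3-methoxyphenyl gives no change at the digits printed from compound 1 to compound 4 (within the scatter) with 4-(tert-butyl)phenyl held in place. No evidence on the cause of these steps is at hand. Open, from the compounds shown here alone, is how a carboxylic acid or a morpholine on this aromatic carbon would read against compound 4 and whether plain phenyl, without the tert-butyl, would hold that level.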